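The source may report more compounds than this note shows. Statements on the series, on what has been measured and on what is new or still open speak of the compounds shown alone.

Measured so far:
compound 1 `CCCCCCCON1C(=O)[C@@H](NC(=O)OCCCCC2CCCCC2)[C@@H]1C` gives 2230 nM in an assay on HEK293 cells for inhibition of N-acylethanolamine-hydrolyzing acid amidase (Homo sapiens), read by fluorescence, with stated times of 10 min and 50 min; a higher number here means a weaker inhibitor, a lower number a stronger inhibitor
compound 2 `C[C@H]1[C@H](NC(=O)OCCCCC2CCCCC2)C(=O)N1Oc1ccc(C(F)(F)F)cc1` gives 31 nM in this assay

Within the data shown here, compound 2 holds the lowest of the two numbers; its only neighbour is compound 1, and the step of a 72-fold lower number from compound 1 to compound 2 (1.86 log units; beyond the scatter) sets them well apart. Compound 3 `C[C@H]1[C@H](NC(=O)OCCCCC2CCCCC2)C(=O)N1Oc1ccccc1S(C)(=O)=O` carries 2-(methylsulfonyl)phenyl in place of 4-(trifluoromethyl)phenyl on an oxygen. Among the measured compounds shown here, the one measured step swapped a chain for an aromatic ring, not one aromatic ring for another, so it bears only loosely here. An aryl-to-aryl exchange of this kind is expected to move the number modestly, most likely upward; the estimated step is a 3.2-fold higher number from compound 2 to compound 3 (0.51 log units; beyond the scatter). Compound 3 is therefore estimated at 100 nM, with a range from 20 nM to 600 nM.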

Compound 3, half-maximal inhibitory concentration: 6 nM
The estimate for compound 3 lay 17-fold (1.22 log units) above the measured number, outside the stated range (below it).
By their numbers in this assay, from the lowest: compound 3; then compound 2; then compound 1.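

Exchanging one aromatic ring for another on this oxygen still moves the number: 2-(methylsulfonyl)phenyl in place of 4-(trifluoromethyl)phenyl gives a 5.2-fold lower number from compound 2 to compound 3 (0.71 log units; beyond the scatter). Against the heptyl chain, the same ring gives a 370-fold lower number from compound 1 to compound 3 (2.57 log units; beyond the scatter), the widest step among these three compounds. Nothing available explains the difference between the two aromatic groups.

The change replaced both the group and its place on the ring, so the two cannot be separated here. On these data alone, whether 2-(methylsulfonyl)phenyl could give way to a phenyl ring carrying an amine or a carboxylic acid and keep the number this low also stays open.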